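This account rests on a few compounds, and the source may have more. Where it says the series, first, only, none or still open, it means among the compounds named here.

Measured so far in a functional assay on A-375 cells (Homo sapiens) for antiproliferative activity, read by MTT assay, with a stated time of 24 h; a higher number here means a weaker inhibitor, a lower number a stronger inhibitor:
- compound 1 `COc1cccc(C(=O)Oc2ccc3c(=O)c(-c4cc(OC)c(OC)cc4OC)coc3c2)c1`: > 10000 nM, a limit of the assay and not a number
- compound 2 `COc1cc(OC)c(-c2coc3cc(OCc4ccc(C#N)cc4)ccc3c2=O)cc1OC`: 1550 nM

Among the compounds with values here, compound 2 holds the only true number in this assay, so there is no measured spread for placing it. Within the data shown here, the one other reading, for compound 1, is a limit.

The next compound is compound 3 `COc1cc(OC)c(-c2coc3cc(OCc4ccc(Cl)cc4)ccc3c2=O)cc1OC`. It keeps the shared core of compound 2 and differs in one place: chloro in place of cyano on an aromatic carbon. This puts chloro in place of cyano on an aromatic carbon, para to a large group, turning 4-cyanobenzyl into 4-chlorobenzyl.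

Among the measured compounds shown here, only one measured step bears on this: an at least 6.4-fold lower number from compound 1 to compound 2 (0.80 log units; beyond the scatter). That step replaced the whole (3-methoxyphenyl)carbonyl group with 4-cyanobenzyl, and one of its ends is a limit. It shows that the group on this oxygen matters, but it does not test a swap of cyano for chloro. With the benzyl group kept, a much smaller step is expected, with no direction favoured by the data. The estimate is a 1.2-fold higher number from compound 2 to compound 3 (0.06 log units; within the scatter), a change not expected to stand clear of the scatter. For compound 3 the expected value is 1800 nM, with an estimated range from 600 nM to 6000 nM.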

Compound 3, half-maximal inhibitory concentration: 1020 nM
Estimate against measurement, compound 3: 1.8-fold (0.25 log units) above; low and high end bracket the measured number.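

In this assay, the nitrile of the 4-cyanobenzyl group is not needed for the activity seen with this side chain: chloro in place of cyano on the aromatic carbon, para to a large group, gives a 1.5-fold lower number from compound 2 to compound 3 (0.18 log units; within the scatter), so compound 2 and compound 3 cannot be told apart. The step away from the (3-methoxyphenyl)carbonyl group now holds for a second benzyl group, with an at least 9.8-fold lower number from compound 1 to compound 3 (0.99 log units; beyond the scatter), and among the compounds shown both benzyl compounds fit this, with none against it. Compound 1 stands at a limit of the assay and not a number, so the true size of both steps from it stays unknown and only their minimum can be read: the limit of > 10000 nM in this assay, at which 1 of the 3 values shown sits.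

With only cyano and chloro shown at this aromatic carbon, it remains open whether any other group there, such as an amine or a carboxylic acid, would move the number beyond the scatter. Also open is whether the oxygen tolerates a longer chain before the aromatic ring, since the shown comparison changes the whole group on that oxygen at once.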